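Methyl to ethyl on the 4-bromo-2-methylphenyl group

The compounds below may be only part of what the source reports. "The series", "measured", "known", "first", "only" and "open" are said of these compounds alone.

compound 1 `CCCCN(CC)c1cc(C)nc2c1NC(=O)CN2c1ccc(Cl)cc1Br`: 2.5 nM
compound 2 `CCCCN(CC)c1cc(C)nc2c1NC(=O)CN2c1ccc(Br)cc1C`: 4.4 nM

For the measured compounds named here, in an assay on HEK-293T cells for displacement of a labelled ligand from corticotropin-releasing factor receptor 1 (Homo sapiens), read by scintillation counting, with a stated time of 2 h (a higher number here means a weaker inhibitor, a lower number a stronger inhibitor), compound 2 gives 4.4 nM, the higher of the two numbers, but the one measured step, a 1.8-fold higher number from compound 1 to compound 2 (0.25 log units; within the scatter), lies within the scatter, so the two compounds stand level. Compound 3 `CCCCN(CC)c1cc(C)nc2c1NC(=O)CN2c1ccc(Br)cc1CC` differs from compound 2 by methyl in place of hydrogen on a saturated chain carbon bound to an aromatic carbon. Going by the values given here, no measured step touches this chain, and the single step known is small. Compound 3 is therefore expected to show a 1.1-fold higher number from compound 2 to compound 3 (0.06 log units; within the scatter), nothing beyond the scatter. The value of compound 3 is estimated at 5 nM, within 1.5 nM to 17 nM.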

Compound 3, inhibition constant: 2.5 nM
The estimate for compound 3 lay 2.0-fold (0.30 log units) above the measured number; low and high end bracket the measured number.
By their numbers in this assay, from the lowest: compounds 1, 3 and 2 (each within the scatter of the next).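

In this assay, methyl in place of hydrogen on this saturated chain carbon bound to an aromatic carbon gives a 1.8-fold lower number from compound 2 to compound 3 (0.25 log units; within the scatter), so the step from methyl to ethyl stays inside the scatter. Taking 4-bromo-2-ethylphenyl in place of 2-bromo-4-chlorophenyl gives no change at the digits printed from compound 1 to compound 3 (within the scatter), which leaves the ethyl compound level with the earlier pair. Nothing available explains these results. On these data alone, whether a longer chain such as propyl would stay level at this place remains open. So does the outcome with an amine or a carboxylic acid on that chain.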